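A few compounds are considered here, and "the series" means these few. Any claim that something is new, unique, unknown or untested is made for them only; others in the source may bear on it.

Measured compounds:
compound 1 `CC1CCN(c2nc(C(F)(F)F)ccc2CNC(=O)Nc2ccc3cccnc3c2)CC1` — 7.1 nM in an assay on isolated protein for antagonist activity at transient receptor potential cation channel subfamily V member 1 (Homo sapiens), read by FLIPR; on this read-out higher numbers stand for weaker inhibition and lower numbers for stronger inhibition
compound 2 `CC1CCN(c2nc(C(F)(F)F)ccc2CNC(=O)Nc2cnc3ccccc3c2)CC1` — 9.5 nM in this assay

Within the data shown here, of the two numbers in this assay, compound 1 stands at the lower one, with compound 2 as its only neighbour; the step from the one to the other, a 1.3-fold higher number from compound 1 to compound 2 (0.13 log units; within the scatter), lies within the usual scatter of such measurements. Compound 3 `CC1CCN(c2nc(C(F)(F)F)ccc2CNC(=O)Nc2cccc3cccnc23)CC1` has not yet been measured in this assay. It differs from compound 1 at one place only: quinolin-8-yl in place of quinolin-7-yl on an amide-type nitrogen. Among the measured compounds shown here, the one measured step that bears on this change is the step from compound 1 to compound 2, where the point at which the quinoline is joined to the amide-type nitrogen was also moved, and that step was small, a 1.3-fold higher number from compound 1 to compound 2 (0.13 log units; within the scatter). On that basis the step from compound 1 to compound 3 in this assay is expected to be small as well, with no direction that can be told apart from the scatter, though the estimate leans slightly towards a higher number. Compound 3 is therefore estimated at 15 nM in this assay, within a range of 5 nM to 50 nM, which corresponds to an expected step of a 2.1-fold higher number from compound 1 to compound 3 (0.32 log units; beyond the scatter).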

Compound 3, inhibition constant: 91.6 nM
The estimate for compound 3 lay 6.1-fold (0.79 log units) below the measured number; measured number above the stated range.
By their numbers in this assay, from the lowest: compounds 1 and 2 (each within the scatter of the next); then compound 3.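

Changing where the quinoline is joined to the amide-type nitrogen is not a neutral change in this assay: quinolin-8-yl in place of quinolin-7-yl gives a 13-fold higher number from compound 1 to compound 3 (1.11 log units; beyond the scatter), and quinolin-8-yl in place of quinolin-3-yl gives a 9.6-fold higher number from compound 2 to compound 3 (0.98 log units; beyond the scatter). The small step between compound 1 and compound 2 therefore does not extend to every point of attachment, and at this position quinolin-8-yl stands apart from the other two quinolines, even though all three carry the same atoms and compound 3 differs from each of the others only in how they are joined. No measurement offered here bears on the reason for this difference.

As far as these compounds go, it remains open whether the higher number belongs to quinolin-8-yl alone or also appears with other points of attachment, such as quinolin-5-yl or quinolin-6-yl. From the compounds shown here alone, it is equally open whether naphthalen-1-yl, an all-carbon ring pair, on the same amide-type nitrogen would give a number close to that of compound 3 or closer to those of compound 1 and compound 2.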